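Glucose-derived amides: carboxy to carbamoylmethyl at the amide-bearing carbon

The source may report more compounds than this note shows. Statements on the series, on what has been measured and on what is new or still open speak of the compounds shown alone.

Measured so far in an assay on isolated protein for binding affinity to E-selectin (Homo sapiens); on this read-out lower numbers stand for stronger inhibition and higher numbers for weaker inhibition:
compound 1 `O=C(O)CC[C@@H](NC(=O)CC1OC(CO)C(O)C(O)C1O)C(=O)O` gives 7000000 nM
compound 2 `O=C(O)C[C@@H](NC(=O)CC1OC(CO)C(O)C(O)C1O)C(=O)O` gives 6000000 nM
compound 3 `O=C(O)CCc1ccc(NC(=O)CC2OC(CO)C(O)C(O)C2O)cc1` gives 10000000 nM

All three share the same sugar acetamide core and differ only in the acid-bearing part attached to the amide nitrogen. On the numbers shown compound 2 has the lowest value, but its gaps to compound 1 and to compound 3 both lie within the scatter, so no ranking among the three can be drawn. For the measured compounds named here, the one single-point step available, a 1.2-fold lower number from compound 1 to compound 2 (0.07 log units; within the scatter), is itself within the scatter.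

Compound 4 `NC(=O)CC[C@@H](NC(=O)CC1OC(CO)C(O)C(O)C1O)C(=O)O` has not yet been measured. It differs from compound 2 by carbamoylmethyl in place of carboxy on a saturated chain carbon, two bonds along the chain from an amide-type nitrogen and a carbonyl carbon, so the acid is replaced by a primary amide one bond further out. Going by the values given here, no measured step swaps an acid for an amide; the only step at this position, a 1.2-fold lower number from compound 1 to compound 2 (0.07 log units; within the scatter), shows that lengthening or shortening the acid chain here left this assay essentially unmoved. With nothing else to go on, no step beyond the scatter is expected.

For compound 4 the expected value in this assay is 6000000 nM, with a range of 2000000 nM to 20000000 nM, which amounts to an estimated step of no change at the digits printed from compound 2 to compound 4 (within the scatter).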

Compound 4, half-maximal inhibitory concentration: > 10000000 nM
Compound 4: no number, only a limit (the forecaster's own chance of this, stated with the estimate: 30%); middle value at least 1.6-fold (0.22 log units) away from the limit.
By their numbers in this assay, from the lowest: compounds 2, 1 and 3 (each within the scatter of the next).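

In this assay, for the compounds shown here, compound 4 gives > 10000000 nM, which is a limit of the assay and not a number, and the only such value in the set: the limit of > 10000000 nM in this assay, at which 1 of the 4 values shown sits. Carbamoylmethyl in place of carboxy on the saturated chain carbon gives an at least 1.6-fold higher number from compound 2 to compound 4 (0.22 log units; that floor lies within the scatter), and amino in place of hydroxy on a carbonyl carbon gives an at least 1.4-fold higher number from compound 1 to compound 4 (0.15 log units; that floor lies within the scatter); both floors lie within the scatter, so neither step establishes a real loss. Going by these compounds alone, what is new is that compound 4, the only compound here whose chain ends in a primary amide rather than a carboxylic acid, shows no sign of a lower number in this assay, though how far its true value lies from those of compound 1 and compound 2 cannot be read.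

Going by these compounds, whether the terminal carboxylic acid of compound 1 contributes anything to binding therefore stays open, and a true number for compound 4 would be needed to settle it. Also open, on these data alone, is what a methyl ester, a primary amine or a longer chain carrying the carboxylic acid would give at this place.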